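The source may report more compounds than this note shows. Statements on the series, on what has been measured and on what is new or still open speak of the compounds shown alone.

In a functional assay on HT-29 cells (Homo sapiens) for cytotoxicity, read by MTT assay, with a stated time of 6 days (on this read-out higher numbers stand for an effect only at larger amounts of compound and lower numbers for an effect already at smaller amounts), compound 1 `COc1ccc2oc(-c3ccc(O)cc3)c(C(=O)O)c(=O)c2c1` gives > 25 ug/mL as a limit of the assay and not as a number. Compound 2 `O=c1cc(-c2ccc([N+](=O)[O-])cc2)oc2ccc(O)cc12` gives > 25 ug/mL as a limit too, and so stands at the limit of > 25 ug/mL in this assay, at which 2 of the 2 values shown sit, with no number of its own. Compound 3 `Nc1ccc(-c2cc(=O)c3cc(O)ccc3o2)cc1` has amino in place of nitro on an aromatic carbon, para to a large group (amino in place of nitro on an aromatic carbon). Among the measured compounds shown here, no measured step sizes this change, so a modest move toward lower numbers is expected, with the estimated step of an at least 1.3-fold lower number from compound 2 to compound 3 (0.14 log units; that floor lies within the scatter) resting on the structural change alone. For compound 3 the estimate is 18 ug/mL with an expected range from 5 ug/mL to 40 ug/mL on this read-out.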

Compound 3, concentration for half-maximal effect: 2.65 ug/mL
Beside the measured number, compound 3's estimate is 6.8-fold (0.83 log units) above it, and the stated range ends above it.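

On the aromatic carbon para to a large group, amino in place of nitro gives an at least 9.4-fold lower number from compound 2 to compound 3 (0.97 log units; beyond the scatter) in this assay and yields the only compound shown with a number of its own. Among the compounds shown here, this is the first change that can be sized. That size is only a floor, because compound 2 holds a limit of the assay and not a number: the limit of > 25 ug/mL in this assay, at which 2 of the 3 values shown sit.

From the compounds shown here alone, whether amino itself or the loss of nitro carries the step stays open. An acetamide, a dimethylamino group or plain hydrogen at this place would separate the two readings.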